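Piperidin-1-yl for pyrrolidin-1-yl on a side chain

The source may report more compounds than this note shows. Statements on the series, on what has been measured and on what is new or still open speak of the compounds shown alone.

In an ADME assay on L6 cells (Rattus norvegicus) for cytotoxicity (a higher number here means a weaker inhibitor, a lower number a stronger inhibitor), compound 1 `CN(C)C12CC(OC(=O)CN3CCCC3)C(C(c3ccccc3)C1)C(c1ccccc1)C2` gives 32700 nM and compound 2 `CN(C)C12CC(OC(=O)CCN3CCCC3)C(C(c3ccccc3)C1)C(c1ccccc1)C2` gives 26000 nM, so compound 2 stands level with compound 1 within the usual scatter. Compound 3 `CN(C)C12CC(OC(=O)CCN3CCCCC3)C(C(c3ccccc3)C1)C(c1ccccc1)C2` differs from compound 2 in one group: piperidin-1-yl in place of pyrrolidin-1-yl on a saturated chain carbon, two bonds along the chain from a carbonyl carbon. This places piperidin-1-yl where pyrrolidin-1-yl stood, on a saturated chain carbon, two bonds along the chain from a carbonyl carbon. Among the compounds with values here, only one measured step touches this chain: a 1.3-fold lower number from compound 1 to compound 2 (0.10 log units; within the scatter), which came from putting (pyrrolidin-1-yl)methyl in place of pyrrolidin-1-yl. Within the data shown here, no measured pair yet changes pyrrolidin-1-yl to piperidin-1-yl, so that small step is only a loose guide, and no shift beyond the scatter is expected. The expected change is a 1.1-fold lower number from compound 2 to compound 3 (0.03 log units; within the scatter). Compound 3 is expected at about 24000 nM, with an estimated range from 10000 nM to 50000 nM.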

Compound 3, half-maximal inhibitory concentration: 25800 nM
The estimate for compound 3 lay 1.1-fold (0.03 log units) below the measured number, and the stated range covers the measured number.
By their numbers in this assay, from the lowest: compounds 3, 2 and 1 (each within the scatter of the next).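

In this assay, replacing the five-membered pyrrolidin-1-yl ring with the six-membered piperidin-1-yl ring, on a saturated chain carbon two bonds along the chain from a carbonyl carbon, gives a 1.0-fold lower number from compound 2 to compound 3 (0.00 log units; within the scatter). Within the data shown here, this is the first direct test of ring size at this position, and within these two compounds, the added ring carbon leaves the number level. Changing the chain and the ring together gives a 1.3-fold lower number from compound 1 to compound 3 (0.10 log units; within the scatter), so the combined change also stays within the scatter, and no information is available to explain these level results.

As far as these compounds go, it remains open whether a morpholine ring or an open-chain amine such as diethylamino at this position would shift the number beyond the scatter. From the compounds shown here alone, a longer chain carrying piperidin-1-yl is an equally open question.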